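The compounds below may be only part of what the source reports. "The series", "measured", "known", "first", "only" and "open" are said of these compounds alone.

Measured compounds:
Compound 1 `Nc1c(C(=O)O)cnn1-c1ccc(CN(Cc2ccc(F)cc2)Cc2ccc(Cl)cc2)cc1`, which in an ADME assay on liver (Mus musculus) for metabolic stability, read by LC-MS, using microsomes and NADPH, with stated times of 5 min and 30 min, tested at 1 uM (on this read-out lower numbers stand for slow clearance and higher numbers for fast clearance), gives 2.1 mL.min-1.g-1.
Compound 2 `Nc1c(C(=O)O)cnn1-c1ccc(CN(Cc2ccc(Cl)cc2)Cc2ccc(F)c(F)c2)cc1`, which in this assay gives 1.2 mL.min-1.g-1.

Within the data shown here, compound 1 holds the higher of these two numbers, but its only neighbour sits within the scatter: a 1.8-fold lower number from compound 1 to compound 2 (0.24 log units; within the scatter). Compound 3 `COc1ccc(CN(Cc2ccc(F)cc2)Cc2ccc(-n3ncc(C(=O)O)c3N)cc2)cc1OC` differs from compound 1 by 3,4-dimethoxyphenyl in place of 4-chlorophenyl on a saturated chain carbon bound to an amine nitrogen. Among the measured compounds shown here, no measured step involves this exchange; the single step available concerns a fluoro for hydrogen and was within the scatter, so it offers no direction here. The step of a 1.4-fold higher number from compound 1 to compound 3 (0.15 log units; within the scatter) is therefore expected to be small and uncertain. For compound 3 the estimate in this assay is 3 mL.min-1.g-1, with a range from 1.2 mL.min-1.g-1 to 7.5 mL.min-1.g-1.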

Compound 3, intrinsic clearance in microsomes: 7.4 mL.min-1.g-1
Compound 3: middle estimate off by 2.5-fold (0.39 log units), on the low side; measured number inside the range.
By their numbers in this assay, from the lowest: compounds 2 and 1 (each within the scatter of the next); then compound 3.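

At the saturated chain carbon bound to an amine nitrogen, 3,4-dimethoxyphenyl in place of 4-chlorophenyl gives a 3.5-fold higher number from compound 1 to compound 3 (0.55 log units; beyond the scatter) in this assay and is the first change shown to move this read-out beyond the scatter. The fluoro for hydrogen step had stayed within it. Nothing available accounts for this rise.

The compounds shown leave open whether the rise follows from both methoxy groups together, from one alone, or from the loss of the chlorine. A 4-methoxyphenyl or an unsubstituted phenyl at this place would help separate these readings.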